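Swapping cyclopropyl for 4-fluorophenyl on a shared core

The compounds below may be only part of what the source reports. "The series", "measured", "known", "first", "only" and "open" are said of these compounds alone.

Of the compounds shown here, three have been measured in a functional assay on SW620/5-FU cells (Homo sapiens) for cytotoxicity, read by MTT assay, with a stated time of 48 h, in the presence of a further agent that is not named here; a lower number here means that less compound is needed, a higher number that more compound is needed for the effect. Compound 1 `Cc1nn(C)c2nc(NNC(=O)Nc3cc(Cl)nc(Cl)c3)cc(C3CC3)c12` gives 80800 nM; compound 2 `CC(C)c1cc(NNC(=O)Nc2cc(Cl)nc(Cl)c2)nc2c1cnn2C` gives 50100 nM; compound 3 `COc1ccc(-c2cc(NNC(=O)Nc3cc(Br)nc(Br)c3)nc3c2cnn3C)cc1` gives 54100 nM. Compound 1 carries the highest of the three numbers, yet its gaps to compound 3 and to compound 2 both lie within the usual scatter, so the three are not separated. Compound 4 `Cc1nn(C)c2nc(NNC(=O)Nc3cc(Cl)nc(Cl)c3)cc(-c3ccc(F)cc3)c12` is not yet measured; it differs from compound 1 by 4-fluorophenyl in place of cyclopropyl on an aromatic carbon. For the measured compounds named here, no directly comparable pair exists among the measured compounds, and the aryl-bearing compound 3 sits within the scatter of compound 1, so no step beyond the scatter is expected in this assay. For compound 4 the expected value is 60000 nM, with a range from 25000 nM to 150000 nM, an expected change of a 1.3-fold lower number from compound 1 to compound 4 (0.13 log units; within the scatter).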

Compound 4, half-maximal effective concentration: 17400 nM
Estimate against measurement, compound 4: 3.4-fold (0.54 log units) above, and the stated range ends above it.
By their numbers in this assay, from the lowest: compound 4; then compounds 2, 3 and 1 (each within the scatter of the next).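

In this assay, for the compounds shown here, 4-fluorophenyl in place of cyclopropyl on the aromatic carbon opposite the ring nitrogen gives a 4.6-fold lower number from compound 1 to compound 4 (0.67 log units; beyond the scatter), the first step beyond the scatter in this set. Going by these compounds alone, this shows that the position responds to a change of group, which the three earlier compounds, with no comparable pair among them, could not show. Nothing given here accounts for the step. From the compounds shown here alone, whether phenyl without the fluorine, an amine or a longer alkyl chain at this position would give a similar step remains open.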